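Swapping the 3-cyanophenyl group of compound 3

The source may report more compounds than this note shows. Statements on the series, on what has been measured and on what is new or still open speak of the compounds shown alone.

Of the compounds shown here, three with a shared core have been read in a functional assay on HT-29 cells (Homo sapiens) for inhibition, read by CCK-8 assay, with a stated time of 24 h; on this read-out lower numbers stand for stronger inhibition and higher numbers for weaker inhibition. Compound 1 `Cc1cccc(-n2cc(-c3ccc(/C=C4\C(=O)Nc5ccccc54)cc3)nn2)c1` gives 3940 nM, and compound 2 `O=C1Nc2ccccc2/C1=C/c1ccc(-c2cn(-c3ccc(F)cc3)nn2)cc1` gives 17700 nM. Compound 3 `N#Cc1cccc(-n2cc(-c3ccc(/C=C4\C(=O)Nc5ccccc54)cc3)nn2)c1` gives > 20000 nM, which is a limit of the assay and not a number, and it stands at the limit of > 20000 nM in this assay, at which 1 of the 3 values shown sits.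

Compound 4 `O=C1Nc2ccccc2/C1=C/c1ccc(-c2cn(-c3ccc(Cl)c(C(F)(F)F)c3)nn2)cc1` differs from compound 3 in one place 4-chloro-3-(trifluoromethyl)phenyl in place of 3-cyanophenyl on an aromatic nitrogen.

Going by the values given here, three measured steps bear on this change, since each alters the group on that same nitrogen. Putting 4-fluorophenyl in place of 3-methylphenyl gave a 4.5-fold higher number from compound 1 to compound 2 (0.65 log units; beyond the scatter). Putting cyano in place of methyl gave an at least 5.0-fold higher number from compound 1 to compound 3 (0.70 log units; beyond the scatter). Putting 3-cyanophenyl in place of 4-fluorophenyl gave an at least 1.1-fold higher number from compound 2 to compound 3 (0.05 log units; that floor lies within the scatter). The first two steps show that changes to this group have moved the read-out by modest amounts, while the third has a floor within the scatter. Among the compounds with values here, none of the measured compounds carries the entering group, so only a modest step to a lower number is expected. The expected step is an at least 2.2-fold lower number from compound 3 to compound 4 (0.34 log units; beyond the scatter). The estimated value for compound 4 is 9000 nM, with an expected range from 2500 nM to 22000 nM.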

Compound 4, half-maximal inhibitory concentration: 9670 nM
The estimate for compound 4 lay 1.1-fold (0.03 log units) below the measured number; the range from low to high includes it.
By their numbers in this assay, from the lowest: compound 1; then compounds 4 and 2 (each within the scatter of the next). At a limit, above all of these: compound 3.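

In this assay, replacing 3-cyanophenyl with 4-chloro-3-(trifluoromethyl)phenyl gives an at least 2.0-fold lower number from compound 3 to compound 4 (0.31 log units; beyond the scatter), which shows that this nitrogen tolerates a group with more heavy atoms and no hydrogen-bond acceptor while still giving a number inside the assay's range. Set against the 4-fluorophenyl group, the same entering group gives a 1.8-fold lower number from compound 2 to compound 4 (0.26 log units; within the scatter), so these two groups cannot be ranked on this read-out. Set against the 3-methylphenyl group, it gives a 2.5-fold higher number from compound 1 to compound 4 (0.39 log units; beyond the scatter), so adding chlorine and trifluoromethyl to the ring does not recover the number held by the 3-methylphenyl group, which stays the lowest of the four.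

Going by these compounds, compound 3 remains a limit of the assay and not a number, so the full size of the step from it stays open: the limit of > 20000 nM in this assay, at which 1 of the 4 values shown sits. Also open, on these data alone, are how much the chlorine and the trifluoromethyl each contribute, and whether an unsubstituted phenyl, an amine or a carboxylic acid on this ring would bring the number below that of compound 1.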